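The compounds below may be only part of what the source reports. "The series", "measured", "known", "first", "only" and "open" are said of these compounds alone.

Working notes on the series. All compounds share one core and differ only at the amine on the saturated chain. Compound 1 `CC(C)NCCS(=O)(=O)NC(=O)c1ccc(Nc2nc(NC3(c4ccc(Cl)cc4)CC3)nc(OCC(F)(F)F)n2)cc1` gives 45 nm/s in a physicochemical assay for permeability, using PAMPA, at pH 7.4; a higher number here means that the compound crosses the layer faster, a lower number that the compound crosses the layer more slowly. Compound 2 `CCS(=O)(=O)NC(=O)c1ccc(Nc2nc(NC3(c4ccc(Cl)cc4)CC3)nc(OCC(F)(F)F)n2)cc1` gives 28 nm/s in this assay; the step is a 1.6-fold lower number from compound 1 to compound 2 (0.21 log units; within the scatter). Compound 3 `CC(C)(C)CNCCS(=O)(=O)NC(=O)c1ccc(Nc2nc(NC3(c4ccc(Cl)cc4)CC3)nc(OCC(F)(F)F)n2)cc1` gives 651 nm/s and stands highest of the three numbers, with a 14-fold higher number from compound 1 to compound 3 (1.16 log units; beyond the scatter) and a 23-fold higher number from compound 2 to compound 3 (1.37 log units; beyond the scatter).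

Compound 4 `NCCS(=O)(=O)NC(=O)c1ccc(Nc2nc(NC3(c4ccc(Cl)cc4)CC3)nc(OCC(F)(F)F)n2)cc1` is not yet measured. The change from compound 3 is hydrogen in place of neopentyl on an amine nitrogen. Among the measured compounds shown here, two measured steps bear on it. The step of a 23-fold higher number from compound 2 to compound 3 (1.37 log units; beyond the scatter) covers the same neopentyl group together with its amine nitrogen and was large; the step of a 14-fold higher number from compound 1 to compound 3 (1.16 log units; beyond the scatter) swaps that group for isopropyl and was also large. Both point the same way: removing the neopentyl is expected to lower the number, with an estimated step of a 22-fold lower number from compound 3 to compound 4 (1.34 log units; beyond the scatter). The values of compound 1 and compound 2 lie within the scatter of each other, so an amine with a small or no substituent gives numbers in that range. Compound 4 is therefore expected at 30 nm/s, within 10 nm/s to 100 nm/s.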

Compound 4, apparent permeability: 153 nm/s
Compound 4: the middle estimate sits 5.1-fold (0.71 log units) below what was measured, and the stated range ends below it.
By their numbers in this assay, from the lowest: compounds 2 and 1 (each within the scatter of the next); then compound 4; then compound 3.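

In this assay, the bare amino group alone separates the series from the compound without an amine, with a 5.5-fold higher number from compound 2 to compound 4 (0.74 log units; beyond the scatter) on this chain, so a high number at this position does not require neopentyl. Hydrogen on the amine nitrogen sits between the two alkyl groups, since a 3.4-fold higher number from compound 1 to compound 4 (0.53 log units; beyond the scatter) marks a rise on losing isopropyl and a 4.3-fold lower number from compound 3 to compound 4 (0.63 log units; beyond the scatter) marks a fall on losing neopentyl, and the direction of this change therefore depends on the group that leaves. No measurement in hand accounts for this order.

The compounds shown leave open whether a straight butyl chain, a cyclohexyl group or a second alkyl group on this amine nitrogen would fall with compound 1 or with compound 3. They also leave open how a carboxylic acid in place of the amine would behave.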